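A few compounds are considered here, and "the series" means these few. Any claim that something is new, unique, unknown or untested is made for them only; others in the source may bear on it.

Compound 1 `CCOC(=O)C1=Cc2ccccc2OC1(OCc1cc(-c2ccc(F)cc2F)no1)C(F)(F)F` was examined in a functional assay on DU-145 cells (Homo sapiens) for inhibition, read by MTT assay, with a stated time of 24 h; a lower number here means a stronger inhibitor, a higher number a weaker inhibitor. In this assay compound 1 returns only a limit of the assay, > 150000 nM. Compound 2 `CCOC(=O)C1=Cc2ccccc2OC1(OCc1cn(-c2ccc([N+](=O)[O-])cc2)nn1)C(F)(F)F` behaves alike: in this assay compound 2 likewise returns only a limit, > 150000 nM. Compound 1 thus stands at the limit of > 150000 nM in this assay, at which 2 of the 2 values shown sit, with no measured number from which a change could be counted. Compound 3 `CCOC(=O)C1=Cc2ccccc2OC1(OCc1cc(-c2ccc(F)cc2)no1)C(F)(F)F` differs from compound 1 by hydrogen in place of fluoro on an aromatic carbon. Among the measured compounds shown here, no step between measured compounds is available. For compound 3 a step of a number no higher from compound 1 to compound 3 (the limit leaves the size open) is expected, nothing beyond the scatter. Compound 3 is therefore estimated at 150000 nM, between 50000 nM and 300000 nM, most probably again only a limit.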

Compound 3, half-maximal inhibitory concentration: 53500 nM
Beside the measured number, compound 3's estimate is 2.8-fold (0.45 log units) above it; measured number inside the range.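

In this assay, among the compounds shown here, the change from 2,4-difluorophenyl to 4-fluorophenyl gives an at least 2.8-fold lower number from compound 1 to compound 3 (0.44 log units; beyond the scatter), the first step that can be read. It shows that the fluoro group on this aromatic carbon, ortho to a large group, matters to the read-out, and that removing it brings a measurable inhibition. Its true size stays open, since compound 1 and compound 2 remain at a limit rather than a number: the limit of > 150000 nM in this assay, at which 2 of the 3 values shown sit.

The compounds shown leave open whether chloro, methoxy or an amine on this carbon would lower the number further. They also leave open what the remaining fluoro group contributes.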